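The source may hold more compounds than are shown below. What is called first, only, known or untested is meant among the compounds shown, and "the series" means these compounds.

Measured so far:
- compound 1, `O[C@H]1Cc2ccccc2C1NC1CCN(CCCc2c[nH]c3ccc(-n4cnnc4)cc23)CC1`: 300 nM
- compound 2, `c1ccc(NCC2CCN(CCCc3c[nH]c4ccc(-n5cnnc5)cc34)CC2)nc1`: 3.3 nM

Both compounds were tested in an assay on CHO cells for displacement of a labelled ligand from 5-hydroxytryptamine receptor 1B (Homo sapiens); a lower number here means a stronger inhibitor, a higher number a weaker inhibitor. Compound 2 holds the lower of the two numbers, and the gap to compound 1 is large: a 91-fold lower number from compound 1 to compound 2 (1.96 log units; beyond the scatter). That step swapped out a much bulkier group on the saturated ring carbon for the ((pyridin-2-yl)amino)methyl group.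

Compound 3, `c1cncc(CNC2CCN(CCCc3c[nH]c4ccc(-n5cnnc5)cc34)CC2)c1`, keeps every atom of compound 2 but joins them differently: ((pyridin-3-yl)methyl)amino in place of ((pyridin-2-yl)amino)methyl on a saturated ring carbon. The nitrogen bearing a hydrogen now sits directly on the ring carbon, and the pyridine is carried on the methylene instead. Within the data shown here, no measured step covers a rearrangement of this kind; the one known step, a 91-fold lower number from compound 1 to compound 2 (1.96 log units; beyond the scatter), changed a wholly different group and so gives only loose guidance. A modest rise in the number is expected, a 4.5-fold higher number from compound 2 to compound 3 (0.66 log units; beyond the scatter), since compound 1 also bears a nitrogen directly on that ring carbon and gives 300 nM. Compound 3 is therefore estimated at 15 nM, between 3 nM and 80 nM.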

Compound 3, half-maximal inhibitory concentration: 140 nM
Estimate against measurement, compound 3: 9.3-fold (0.97 log units) below, and the stated range ends below it.
By their numbers in this assay, from the lowest: compound 2; then compound 3; then compound 1.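

Compound 2 and compound 3 have the same atoms and the same counts of donors and acceptors, yet the rearrangement gives a large change (a 42-fold higher number from compound 2 to compound 3 (1.63 log units; beyond the scatter)), so on this saturated ring carbon the way the atoms are joined matters, not only which atoms are present. Compound 1 and compound 3 both carry the amine nitrogen directly on that ring carbon, and exchanging 2-hydroxy-2,3-dihydro-1H-inden-1-yl for the much smaller (pyridin-3-yl)methyl on that nitrogen moves the number only modestly (a 2.1-fold lower number from compound 1 to compound 3 (0.33 log units; beyond the scatter)). Nothing available explains these differences.

As far as these compounds go, the step from compound 2 to compound 3 alters both the linker and the point of attachment on the pyridine, so their separate shares remain open. A ((pyridin-3-yl)amino)methyl group on the same ring carbon would separate them, and a phenyl ring in place of the pyridine would test whether the pyridine nitrogen matters.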